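The source may hold more compounds than are shown below. What is called first, only, known or untested is meant among the compounds shown, and "the series" means these compounds.

Compound 1 `COc1cccc(CCC(=O)Nc2nc3ccccc3c(=O)s2)c1` and compound 2 `O=C(CCc1ccccc1F)Nc1nc2ccccc2c(=O)s1` share the same core and the same three-carbon amide chain; they differ only in the aromatic group that hangs from the end of that chain. In an assay on membranes from brain for displacement of a labelled ligand from adenosine receptor A1 (Rattus norvegicus), read by scintillation counting, with a stated time of 90 min (a higher number here means a weaker inhibitor, a lower number a stronger inhibitor), compound 1 gives 367 nM. Compound 2 gives only a limit of the assay, > 10000 nM, so its true number is not known. Within the data shown here, the one measured step, an at least 27-fold higher number from compound 1 to compound 2 (1.43 log units; beyond the scatter), is therefore a lower bound, and it rests on (the limit of > 10000 nM in this assay, at which 1 of the 2 values shown sits). Compound 2 thus stands at the weak end of what has been measured so far.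

Compound 3 `O=C(CCCc1cccc(Cl)c1)Nc1nc2ccccc2c(=O)s1` is the next compound to be tested. It differs from compound 2 by 3-chlorobenzyl in place of 2-fluorophenyl on a saturated chain carbon, two bonds along the chain from a carbonyl carbon. Among the measured compounds shown here, no measured step gives the size of this change directly, since compound 2 sits at a limit. For the measured compounds named here, the only guide is that compound 1, which also carries a substituent in the 3-position of its ring, reaches 367 nM. Compound 3 is therefore expected to improve on compound 2 by roughly an at least 5.0-fold lower number from compound 2 to compound 3 (0.69 log units; beyond the scatter) in this assay, though a second limit cannot be ruled out. The estimate for compound 3 is 2000 nM, within a range from 300 nM to 12000 nM.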

Compound 3, inhibition constant: 898 nM
Compound 3: the middle estimate sits 2.2-fold (0.35 log units) above what was measured; the measured number falls inside the stated range.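

Replacing 2-fluorophenyl with 3-chlorobenzyl on this saturated chain carbon restores clear binding in this assay, giving an at least 11-fold lower number from compound 2 to compound 3 (1.04 log units; beyond the scatter). Going by these compounds, the true size of that gain is unknown, and it can only be read as a lower bound, because compound 2 sits at a limit of the assay: the limit of > 10000 nM in this assay, at which 1 of the 3 values shown sits. Among these compounds, the comparison with the other measured compound gives a 2.4-fold higher number from compound 1 to compound 3 (0.39 log units; beyond the scatter), so 3-methoxyphenyl is not the only group at the end of the chain that gives a measured number, although the change to 3-chlorobenzyl costs a modest amount of binding.

The compounds shown do not reveal which part of the change from compound 2 to compound 3 matters most, since the halogen, its place on the ring and the link to the ring all differ at once, and a pair such as 3-chlorophenyl and 3-fluorophenyl would be needed to separate these. They also leave open how this position responds to an unsubstituted benzyl group, a longer chain carrying the same 3-chlorophenyl ring, or an amine on the ring.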